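From nitro to iodo on the aromatic ring

The source may hold more compounds than are shown below. What is called first, only, known or untested is meant among the compounds shown, and "the series" means these compounds.

Of the compounds shown here, two have numbers so far. In a functional assay on T98G cells (Homo sapiens) for cytotoxicity, read by MTT assay, with a stated time of 48 h (on this read-out lower numbers stand for stronger inhibition and higher numbers for weaker inhibition), compound 2 (`C/C(=N/NC(=S)Nc1cccc([N+](=O)[O-])c1)c1ccccn1`) gives 140 nM as the higher of the two. Compound 1 (`CC(=NNC(=S)Nc1cccc(I)c1)c1ccccn1`) gives 61 nM in the same test, lower than compound 2 by more than the usual scatter.

The next step leads to compound 3 (`C/C(=N/NC(=S)Nc1cccc(I)c1)c1ccccn1`) and consists of one structural change iodo in place of nitro on an aromatic carbon with iodo in place of nitro on an aromatic carbon. Going by the values given here, no measured pair isolates this change. The expectation rests on compound 1, which bears iodo at the same place and gives 61 nM in this assay as the closest reference. A lower number beyond the scatter is expected, with the estimated 2.3-fold lower number from compound 2 to compound 3 (0.37 log units; beyond the scatter) as its size. Compound 3 is expected at 60 nM (estimated range 30 nM to 120 nM).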

Compound 3, half-maximal inhibitory concentration: 61 nM
Compound 3: middle estimate off by 1.0-fold (0.01 log units), on the low side; the range from low to high includes it.
By their numbers in this assay, from the lowest: compounds 1 and 3 (each within the scatter of the next); then compound 2.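

Iodo in place of nitro on an aromatic carbon now stands as a matched pair in this assay, with a 2.3-fold lower number from compound 2 to compound 3 (0.36 log units; beyond the scatter). Compound 2 and compound 3 are drawn alike at the double bond, so this step reads as the change of the aromatic group alone. The second pair shows no change at the digits printed from compound 1 to compound 3 (within the scatter), and the two compounds are separated only by how they are drawn: the fact that one of compounds 1 and 3 is drawn with a defined configuration and the other without, at the place where they differ

The compounds shown leave open how an amine or a carboxylic acid at this place would compare with iodo and nitro, and whether iodo elsewhere on the ring would read like compound 3. From the compounds shown here alone, whether compound 1 is one form or a mixture also stays open, and with it how the opposite configuration at the double bond would read.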